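Notes on the step from compound 2 to compound 3

The source may hold more compounds than are shown below. What is called first, only, known or untested is meant among the compounds shown, and "the series" means these compounds.

- compound 1 `COc1cc2c(Oc3ccc(NC(=O)Nc4ccccc4Cl)cc3)ccnc2cc1OCCCCCCC(=O)NO`: 2780 nM
- compound 2 `COc1cc2c(Oc3ccc(NC(=O)N/N=C/c4ccc(F)cc4)cc3)ccnc2cc1OCCCCCCC(=O)NO`: 1360 nM
- compound 3 `COc1cc2c(Oc3ccc(NC(=O)NNC(=O)c4ccccc4F)cc3)ccnc2cc1OCCCCCCC(=O)NO`: not yet measured

In a functional assay on MCF7 cells (Homo sapiens) for antiproliferative activity, read by MTT assay (on this read-out higher numbers stand for weaker inhibition and lower numbers for stronger inhibition), compound 2 holds the lower of the two numbers at 1360 nM, and compound 1 stands higher at 2780 nM. The change to compound 3 is a group of 10 heavy atoms (7 carbon, 1 nitrogen, 1 oxygen, 1 fluorine; one six-membered aromatic ring of carbon only) in place of a group of 9 heavy atoms (7 carbon, 1 nitrogen, 1 fluorine; one six-membered aromatic ring of carbon only), on an amide-type nitrogen. The entering group is ((2-fluorophenyl)carbonyl)amino, and it adds a hydrogen-bond donor. Among the measured compounds shown here, the only measured step at this amide-type nitrogen is a 2.0-fold lower number from compound 1 to compound 2 (0.31 log units; beyond the scatter), which is modest. That single step gives no firm direction for a different group, so only a small change in this assay is expected, leaning slightly towards a higher number. The expected step is a 1.3-fold higher number from compound 2 to compound 3 (0.12 log units; within the scatter). Compound 3 is estimated at 1800 nM, with an expected range of 650 nM to 5000 nM.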

Compound 3, half-maximal inhibitory concentration: 3600 nM
The estimate for compound 3 lay 2.0-fold (0.30 log units) below the measured number; the measured number falls inside the stated range.
By their numbers in this assay, from the lowest: compound 2; then compounds 1 and 3 (each within the scatter of the next).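

In this assay, ((2-fluorophenyl)carbonyl)amino on the amide-type nitrogen, in place of the group in compound 2, gives a 2.6-fold higher number from compound 2 to compound 3 (0.42 log units; beyond the scatter) and so runs against a 2.0-fold lower number from compound 1 to compound 2 (0.31 log units; beyond the scatter) at the same nitrogen. This shows that the read-out responds to a change between two groups of similar heavy-atom count, each with one six-membered aromatic ring of carbon only and one fluorine. Set against the 2-chlorophenyl group, the same entering group gives a 1.3-fold higher number from compound 1 to compound 3 (0.11 log units; within the scatter), leaving compound 2 alone apart from the other two at this nitrogen. No evidence bears on the cause of these differences.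

The hydrogen-bond donor and the carbonyl enter together in compound 3, so the compounds shown cannot assign the step to either. Also open, as far as these compounds go, is how the read-out responds at this nitrogen to a group with no aromatic ring, such as a simple amine or a carboxylic acid.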